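Working notes: from compound 2 to compound 3

The source may hold more compounds than are shown below. What is called first, only, known or untested is meant among the compounds shown, and "the series" means these compounds.

Measured so far in a functional assay on J774.A1 cells (Mus musculus) for inhibition, read by Griess assay, with stated times of 1 h and 24 h; a lower number here means a stronger inhibitor, a higher number a weaker inhibitor:
- compound 1 `CC(C)COc1ccccc1C1CC(=O)c2ccccc2O1`: 33200 nM
- compound 2 `O=C1CC(c2ccccc2O)Oc2ccccc21`: 71300 nM

Compound 2 has the higher of the two numbers, making it the weaker inhibitor of the pair. Compound 3 `O=C1CC(c2ccccc2OCc2cccc(F)c2)Oc2ccccc21` keeps the shared core and differs from compound 2 as follows: 3-fluorobenzyl in place of hydrogen on an oxygen on an aromatic ring. In words, 3-fluorobenzyl stands in place of hydrogen on an oxygen on an aromatic ring.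

Among the measured compounds shown here, only one measured step bears on this change: a 2.1-fold higher number from compound 1 to compound 2 (0.33 log units; beyond the scatter). That step is modest but beyond the scatter. Compound 1, at 33200 nM, carries isobutyl on that oxygen and has the lower number. A step of similar modest size towards a lower number is therefore expected in this assay, although one pair with a different group supports this only loosely. The expected step is a 2.2-fold lower number from compound 2 to compound 3 (0.33 log units; beyond the scatter). Compound 3 is estimated at 33000 nM, with an expected range of 11000 nM to 80000 nM.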

Compound 3, half-maximal inhibitory concentration: 13200 nM
The estimate for compound 3 lay 2.5-fold (0.40 log units) above the measured number; measured number inside the range.
By their numbers in this assay, from the lowest: compound 3; then compound 1; then compound 2.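

In this assay, 3-fluorobenzyl in place of hydrogen on the oxygen on an aromatic ring gives a 5.4-fold lower number from compound 2 to compound 3 (0.73 log units; beyond the scatter), so the gain on capping this oxygen is not confined to isobutyl. The two capping groups are also not interchangeable: 3-fluorophenyl in place of isopropyl on the saturated chain carbon bound to that oxygen gives a 2.5-fold lower number from compound 1 to compound 3 (0.40 log units; beyond the scatter), and both capped compounds have lower numbers than the free hydroxyl compound, with none of the three going against this. No measurement at hand accounts for these differences.

The compounds shown leave open whether the gain belongs to the aromatic ring or to its fluorine, a question that plain benzyl or 4-fluorobenzyl on the same oxygen would address. Also open, on these data alone, is how a chain ending in an amine or a carboxylic acid would read at this position.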